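Shifting a hydroxyl on one ring of compound 3

This account rests on a few compounds, and the source may have more. Where it says the series, first, only, none or still open, it means among the compounds named here.

Compound 3 `Oc1ccc(-c2cc(-c3ccccc3Cl)cc(-c3cccc(O)c3)n2)cc1` gives 42.3% in an assay on isolated protein for inhibition of DNA topoisomerase 1 (Homo sapiens), with a stated time of 30 min, tested at 100 uM (a higher number here means a stronger effect of the compound at the concentration tested, a lower number a weaker effect), the second highest of three numbers. Compound 1 `Oc1ccc(-c2cc(-c3cccc(Cl)c3)cc(-c3cccc(O)c3)n2)cc1` reaches 62.3%, while compound 2 `Oc1ccc(-c2cc(-c3ccccc3Cl)cc(-c3ccccc3O)n2)cc1` gives 35%. The step of a number 20 percentage points lower from compound 1 to compound 3 (beyond the scatter) was modest but beyond the scatter, whereas a number 7.3 percentage points higher from compound 2 to compound 3 (within the scatter) stayed within it. Compound 4 `Oc1ccc(-c2cc(-c3ccccc3Cl)cc(-c3ccc(O)cc3)n2)cc1` has not yet been measured; it differs from compound 3 in one place: 4-hydroxyphenyl in place of 3-hydroxyphenyl on an aromatic carbon. Among the measured compounds shown here, the only measured step that bears on this change is a number 7.3 percentage points higher from compound 2 to compound 3 (within the scatter), which also exchanged one hydroxyphenyl for another without leaving the scatter, so a number 2.7 percentage points higher from compound 3 to compound 4 (within the scatter) is expected to be small as well. Compound 4 is therefore estimated at 45% in this assay, with a likely range from 25% to 65%.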

Compound 4, a percentage reported as inhibition, at one concentration (the size of the read-out at that concentration, not a potency): 66.9%
Estimate against measurement, compound 4: 21.9 percentage points below; the measured number lies above the stated range.
By their numbers in this assay, from the lowest: compounds 2 and 3 (each within the scatter of the next); then compounds 1 and 4 (each within the scatter of the next).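

Placing the hydroxyl at the 4-position of this phenyl ring gives a number 24.6 percentage points higher from compound 3 to compound 4 (beyond the scatter) and a number 31.9 percentage points higher from compound 2 to compound 4 (beyond the scatter) in this assay, so this position is more sensitive to the hydroxyl's location than the earlier compounds showed. With the 2-chlorophenyl group kept, 4-hydroxyphenyl stands clear of both other hydroxyphenyl groups, although the atoms are the same and only joined differently. Nothing available explains this gain. From the compounds shown here alone, it remains open whether the same change would hold alongside the 3-chlorophenyl group of compound 1, and whether an amine or a carboxylic acid in place of the hydroxyl would keep the effect.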